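Alpha-ketooxazole series: tetrazole to chloro at the oxazole

This account rests on a few compounds, and the source may have more. Where it says the series, first, only, none or still open, it means among the compounds named here.

Measured so far in an assay (Rattus norvegicus) for inhibition of Fatty-acid amide hydrolase 1 (Homo sapiens); a higher number here means a weaker inhibitor, a lower number a stronger inhibitor:
compound 1 `NC(=O)c1cccc(-c2cnc(C(=O)CCCCCCc3ccccc3)o2)n1` gives 1 nM
compound 2 `O=C(CCCCCCc1ccccc1)c1ncc(-c2ccncn2)o1` gives 2.3 nM
compound 3 `O=C(CCCCCCc1ccccc1)c1ncc(-c2nnn[nH]2)o1` gives 63 nM

Compound 3 stands highest of the three numbers; its nearest neighbour is compound 2, reached by a 27-fold higher number from compound 2 to compound 3 (1.44 log units; beyond the scatter), and compound 1 lies furthest, reached by a 63-fold higher number from compound 1 to compound 3 (1.80 log units; beyond the scatter). The change from compound 1 to compound 2 was a 2.3-fold higher number from compound 1 to compound 2 (0.36 log units; beyond the scatter).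

Compound 4 `O=C(CCCCCCc1ccccc1)c1ncc(Cl)o1` differs from compound 3 in one place: chloro in place of 1H-tetrazol-5-yl on an aromatic carbon. Among the compounds with values here, no measured step swaps an aromatic ring at this carbon for a single halogen atom, so no step covers the change directly. What the steps do show is that the group at this carbon moves this assay over a wide span, and that the smallest ring among the three, the tetrazole of compound 3, gives the highest number. Removing the ring altogether is therefore expected to push the number further up, with a wide uncertainty.

The number for compound 4 in this assay is estimated at 400 nM, within 60 nM to 2500 nM. This corresponds to an expected step of a 6.3-fold higher number from compound 3 to compound 4 (0.80 log units; beyond the scatter).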

Compound 4, inhibition constant: 5 nM
The estimate for compound 4 lay 80-fold (1.90 log units) above the measured number; the whole stated range lies above it.
By their numbers in this assay, from the lowest: compound 1; then compound 2; then compound 4; then compound 3.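

In this assay an aromatic ring at this carbon is not required for a low number: chloro, with no ring and 0 hydrogen-bond donors, gives a 13-fold lower number from compound 3 to compound 4 (1.10 log units; beyond the scatter) and so recovers most of the ground lost with the 1H-tetrazol-5-yl group. Against the two larger rings the steps are modest, with a 2.2-fold higher number from compound 2 to compound 4 (0.34 log units; beyond the scatter) and a 5.0-fold higher number from compound 1 to compound 4 (0.70 log units; beyond the scatter) both still beyond the scatter, so among these four compounds the presence of a ring at this carbon does not order the numbers, and the 1H-tetrazol-5-yl group stands apart. Nothing given here bears on the cause of these steps.

Open, going by these compounds, is whether bromo, fluoro, a methyl or an amine at this carbon would track with chloro or with the tetrazole. Also open, on these data alone, is whether a carboxylic acid there would share the high number of compound 3.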